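A Trifluoromethyl Swap in the Chlorophenyl Amine Series

The source may hold more compounds than are shown below. What is called first, only, known or untested is meant among the compounds shown, and "the series" means these compounds.

Among the compounds measured so far, compound 3 `COc1ccc(-c2nc(C(=O)/C=C\Nc3ccc(Cl)cc3)c3ccccn23)cc1` gives the lowest of the two numbered values in a functional assay on B16-F10 cells (Mus musculus) for cytotoxicity, read by MTT assay, with a stated time of 48 h (on this read-out higher numbers stand for weaker inhibition and lower numbers for stronger inhibition), at 1240 nM. Its nearest neighbour is compound 1 `COc1ccc(-c2nc(C(=O)/C=C\Nc3ccc4[nH]ccc4c3)c3ccccn23)cc1`, which in this assay gives 5120 nM; putting 4-chlorophenyl in place of 1H-indol-5-yl on an amine nitrogen brought a 4.1-fold lower number from compound 1 to compound 3 (0.62 log units; beyond the scatter). Compound 2 `O=C(/C=C\Nc1ccc2cc[nH]c2c1)c1nc(-c2ccc(C(F)(F)F)cc2)n2ccccc12` reaches in this assay a limit and not a number, > 30000 nM.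

Compound 4 `O=C(/C=C\Nc1ccc(Cl)cc1)c1nc(-c2ccc(C(F)(F)F)cc2)n2ccccc12` has not yet been measured; it differs from compound 3 by trifluoromethyl in place of methoxy on an aromatic carbon. Going by the values given here, no measured step covers this change directly, but compounds 1 and 2 show the same change within the indolyl series, where the methoxy compound sits at a numbered value and the trifluoromethyl compound sits at the limit of > 30000 nM in this assay, at which 1 of the 3 values shown sits. A weakening of uncertain size is therefore expected, and compound 4 is estimated to take a 6.5-fold higher number from compound 3 to compound 4 (0.81 log units; beyond the scatter). Compound 4 is expected to give about 8000 nM in this assay, within a range from 2500 nM to 30000 nM.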

Compound 4, half-maximal inhibitory concentration: > 30000 nM
Compound 4: no number, only a limit; the forecaster's own chance of this, stated with the estimate: 25%; at least 3.7-fold (0.57 log units) between middle value and limit.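

Going by these compounds alone, with the 4-chlorophenyl amine held fixed, trifluoromethyl in place of methoxy gives an at least 24-fold higher number from compound 3 to compound 4 (1.38 log units; beyond the scatter) in this assay, the first reading of this change between two compounds that differ only there. The 4-chlorophenyl amine, which carries the lowest number shown when paired with 4-methoxyphenyl, therefore does not preserve a numbered value when paired with 4-(trifluoromethyl)phenyl. Both trifluoromethyl compounds shown now end at a limit and not at a number: the limit of > 30000 nM in this assay, at which 2 of the 4 values shown sit.

The step from compound 2 to compound 4 cannot be read, which leaves the influence of the amine partner on the trifluoromethyl compounds unresolved. Also open, going by these compounds, is whether a single fluorine, a chlorine, a methyl group or a hydroxyl group on this aromatic carbon would retain a numbered value with the 4-chlorophenyl amine.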